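The compounds below may be only part of what the source reports. "The series", "measured", "known", "first", "only" and "open" are said of these compounds alone.

Compound 1 `CCCCCCCCS(=O)(=O)Nc1cc(-c2ccc(CCCC)cc2)ccc1C(=O)O`: 15700 nM
Compound 2 `CCCCCCCCS(=O)(=O)Nc1cc(-c2ccc(-c3ccccc3)cc2)ccc1C(=O)O`: 13500 nM
Compound 3 `CCCCCCCCS(=O)(=O)Nc1ccc(C(=O)c2ccc(CCCC)cc2)cc1C(=O)O`: 31700 nM

These three compounds were tested in an assay on mitochondria (strain BALB/c) for inhibition of glycerol-3-phosphate acyltransferase 1, mitochondrial (Mus musculus), read by scintillation counting, with a stated time of 10 min; a lower number here means a stronger inhibitor, a higher number a weaker inhibitor. Compound 2 differs from compound 1 by phenyl in place of butyl on an aromatic carbon, and that change gave a 1.2-fold lower number from compound 1 to compound 2 (0.07 log units; within the scatter). In this assay compound 3 gives the highest number of the three; the difference between its core and the core of compound 1 is not broken down here. Compound 4 `CCCCCCCCS(=O)(=O)Nc1ccc(C(=O)c2ccc(-c3ccccc3)cc2)cc1C(=O)O` has not yet been measured. Within the data shown here, it differs from compound 3 by phenyl in place of butyl on an aromatic carbon, which is the same change as the one between compound 1 and compound 2, made at the same kind of place. Because a 1.2-fold lower number from compound 1 to compound 2 (0.07 log units; within the scatter), the step is expected to be small as well, a 1.2-fold lower number from compound 3 to compound 4 (0.07 log units; within the scatter). On that basis compound 4 is estimated at 27000 nM, most likely between 12000 nM and 60000 nM.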

Compound 4, half-maximal inhibitory concentration: 13000 nM
Beside the measured number, compound 4's estimate is 2.1-fold (0.32 log units) above it; low and high end bracket the measured number.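

In this assay, phenyl in place of butyl gave a 2.4-fold lower number from compound 3 to compound 4 (0.39 log units; beyond the scatter), a modest step. Set beside the earlier step, the change carries from one core to the other with no difference that can be told apart from scatter: the same change on two cores in this assay, a 1.2-fold lower number (0.07 log units; within the scatter) from compound 1 to compound 2 and a 2.4-fold lower number (0.39 log units; beyond the scatter) from compound 3 to compound 4, 2.1-fold (0.32 log units) apart, within the scatter of two such steps. Among these compounds, this rests on only two pairs in a single assay, so it does not show that the step would be the same on other cores, and the earlier step lies within the scatter while this one lies beyond it.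

The compounds shown leave open how other groups at this place, such as an amine or a longer chain, would compare with butyl and phenyl. They also leave open whether the step would hold on any further core.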